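This account rests on a few compounds, and the source may have more. Where it says the series, first, only, none or still open, it means among the compounds named here.

Of the compounds shown here, three sharing one core have been measured in an assay on LtK cells with ATP-sensitive inward rectifier potassium channel 11 (Homo sapiens) as the target; a lower number here means that less compound is needed, a higher number that more compound is needed for the effect. Compound 1 `CC(=O)Nc1c(C(O)(C(F)(F)F)C(F)(F)F)ccc2ccccc12` gives 18 nM, and compound 2 `CCC(=O)Nc1c(C(O)(C(F)(F)F)C(F)(F)F)ccc2ccccc12` gives 15 nM; the step of a 1.2-fold lower number from compound 1 to compound 2 (0.08 log units; within the scatter) stays within the scatter. Compound 3 `CCC(C)C(=O)Nc1c(C(O)(C(F)(F)F)C(F)(F)F)ccc2ccccc12` gives 177000 nM, the highest number of the three, set apart from the others by the steps of a 9800-fold higher number from compound 1 to compound 3 (3.99 log units; beyond the scatter) and a 12000-fold higher number from compound 2 to compound 3 (4.07 log units; beyond the scatter). Compound 4 `CC(C)=CC(=O)Nc1c(C(O)(C(F)(F)F)C(F)(F)F)ccc2ccccc12` has not yet been measured. Its change from compound 3 is 2-methylprop-1-en-1-yl in place of sec-butyl on a carbonyl carbon, so the group on the carbonyl carbon keeps the same count of carbon atoms but now holds a double bond. Going by the values given here, the only measured steps that bear on this are the two into compound 3, both very large rises in the number; no measured compound carries a double bond on the carbonyl carbon, so the direction is uncertain. A number somewhat lower than that of compound 3 is expected, with a wide range. Compound 4 is estimated at 20000 nM, between 500 nM and 300000 nM. That expected step is an 8.9-fold lower number from compound 3 to compound 4 (0.95 log units; beyond the scatter).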

Compound 4, half-maximal effective concentration: 46 nM
For compound 4 the middle estimate is 430-fold (2.64 log units) above the measured one; the whole stated range lies above it.
By their numbers in this assay, from the lowest: compounds 2 and 1 (each within the scatter of the next); then compound 4; then compound 3.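

In this assay, a group on the carbonyl carbon with as many carbons as sec-butyl is compatible with a low number, as replacing sec-butyl with 2-methylprop-1-en-1-yl gives a 3800-fold lower number from compound 3 to compound 4 (3.59 log units; beyond the scatter) and thus reverses nearly all of the earlier rise. Carbon count alone therefore does not decide the result at this position. Compound 4 does not fully match the smaller acyl compounds, with a 3.1-fold higher number from compound 2 to compound 4 (0.49 log units; beyond the scatter) and a 2.6-fold higher number from compound 1 to compound 4 (0.41 log units; beyond the scatter) as its modest remaining gaps.

The compounds shown cannot separate the double bond from the different branching, and a straight butyl chain or a cyclopropyl group on the carbonyl carbon could help to tell these apart. No supporting data are available to explain why these two groups of equal carbon count give such different numbers.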